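Compound 3 to compound 4: an isomeric group swap

The source may hold more compounds than are shown below. What is called first, only, known or untested is meant among the compounds shown, and "the series" means these compounds.

In a functional assay on A549 cells (Homo sapiens) for cytotoxicity, read by MTT assay, with a stated time of 24 h (on this read-out higher numbers stand for weaker inhibition and lower numbers for stronger inhibition), compound 1 `Nc1n[nH]c2nc(C(F)(F)F)ccc12` gives 22400 nM, compound 2 `Nc1nc(C(F)(F)F)cc(=O)n1Cc1cn(-c2n[nH]c3nc(C(F)(F)F)ccc23)nn1` gives 9500 nM and compound 3 `Nc1nc(C(F)(F)F)cc(=O)n1Cc1cn(-c2nn(CCC(F)(F)C(F)(F)C(F)(F)C(F)(F)C(F)(F)C(F)(F)C(F)(F)C(F)(F)F)c3nc(C(F)(F)F)ccc23)nn1` gives 68200 nM. That last number is the highest of the three, beyond the scatter from both others. Compound 4 `Nc1nc(OCc2cn(-c3nn(CCC(F)(F)C(F)(F)C(F)(F)C(F)(F)C(F)(F)C(F)(F)C(F)(F)C(F)(F)F)c4nc(C(F)(F)F)ccc34)nn2)cc(C(F)(F)F)n1` holds the same atoms as compound 3, joined differently: a group of 12 heavy atoms (5 carbon, 3 nitrogen, 1 oxygen, 3 fluorine; one six-membered aromatic ring with 2 hetero atoms) in place of a group of 12 heavy atoms (5 carbon, 3 nitrogen, 1 oxygen, 3 fluorine; one six-membered aromatic ring with 2 hetero atoms), on a saturated chain carbon bound to an aromatic carbon. The entering group is (2-amino-6-(trifluoromethyl)pyrimidin-4-yl)oxy. Going by the values given here, no measured pair isolates this change, so the expectation is only a small shift toward stronger inhibition in this assay, possibly not beyond the scatter. The expected step is a 1.5-fold lower number from compound 3 to compound 4 (0.18 log units; within the scatter). For compound 4 the estimate is 45000 nM, with an expected range from 18000 nM to 110000 nM.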

Compound 4, half-maximal inhibitory concentration: 33700 nM
Compound 4: the middle estimate sits 1.3-fold (0.13 log units) above what was measured; measured number inside the range.
By their numbers in this assay, from the lowest: compound 2; then compounds 1 and 4 (each within the scatter of the next); then compound 3.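

At the saturated chain carbon bound to an aromatic carbon, placing (2-amino-6-(trifluoromethyl)pyrimidin-4-yl)oxy in this assay gives a 2.0-fold lower number from compound 3 to compound 4 (0.31 log units; beyond the scatter) with no change in atom count, a modest step. How the same atoms are joined at this place therefore registers in this read-out, which compounds 1, 2 and 3 could not show. No available evidence accounts for the step.

From the compounds shown here alone, whether an amine link in place of the oxy link would shift the number further remains open. Also open, going by these compounds, is whether the same swap on compound 2 would give a step of similar size.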